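A few compounds are considered here, and "the series" means these few. Any claim that something is new, unique, unknown or untested is made for them only; others in the source may bear on it.

Measured in a functional assay on PC-9 cells (Homo sapiens) for inhibition, read by MTT assay, with a stated time of 72 h; a higher number here means a weaker inhibitor, a lower number a stronger inhibitor:
- compound 1 `Cc1cc(Nc2cc(-c3ccccc3)[nH]n2)n2nc(SCc3c(Cl)cccc3Cl)nc2n1` gives 5180 nM
- compound 2 `Cc1cc(Nc2cc(-c3ccccc3)[nH]n2)n2nc(SCc3ccc(Br)cc3)nc2n1` gives 4760 nM
- compound 3 `Cc1cc(Nc2cc(-c3ccccc3)[nH]n2)n2nc(SCc3cccc4ccccc34)nc2n1` gives 3950 nM

Compound 1 carries the highest of the three numbers, but every gap to it is small: the nearest is a 1.1-fold lower number from compound 1 to compound 2 (0.04 log units; within the scatter) and the furthest is a 1.3-fold lower number from compound 1 to compound 3 (0.12 log units; within the scatter), both within the scatter, and the remaining pair is a 1.2-fold lower number from compound 2 to compound 3 (0.08 log units; within the scatter), likewise within the scatter. All three compounds share one core and differ only in the aryl group on the saturated chain carbon bound to a sulfur, and none of those swaps moved this assay beyond its noise.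

Compound 4 `COc1ccc(CSc2nc3nc(C)cc(Nc4cc(-c5ccccc5)[nH]n4)n3n2)cc1` is not yet measured. Against compound 1 the change is 4-methoxyphenyl in place of 2,6-dichlorophenyl on a saturated chain carbon bound to a sulfur. This is a further swap of the same kind at the same place as the three steps above, each of which stayed within the scatter; one hydrogen-bond acceptor enters here, for which no comparison is available among the measured compounds. On this basis the step of a 1.1-fold lower number from compound 1 to compound 4 (0.05 log units; within the scatter) is expected to lie within the scatter, with no direction beyond it. Compound 4 is therefore estimated at 4600 nM, with a range from 2300 nM to 9500 nM.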

Compound 4, half-maximal inhibitory concentration: 8110 nM
Compound 4: middle estimate off by 1.8-fold (0.25 log units), on the low side; the measured number falls inside the stated range.
By their numbers in this assay, from the lowest: compounds 3, 2, 1 and 4 (each within the scatter of the next, the first and the last beyond it).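

Among the compounds shown here, this position is not entirely flat in this assay: the earlier swaps all stayed within the scatter, whereas 4-methoxyphenyl in place of naphthalen-1-yl gives the first step beyond it, and a modest one (a 2.1-fold higher number from compound 3 to compound 4 (0.31 log units; beyond the scatter)). The other two steps remain within the scatter (a 1.6-fold higher number from compound 1 to compound 4 (0.19 log units; within the scatter); a 1.7-fold higher number from compound 2 to compound 4 (0.23 log units; within the scatter)), the second being methoxy in place of bromo on an aromatic carbon, so only compound 3 and compound 4 separate, while compound 1 and compound 2 separate from neither. No measurement here accounts for the step, and the hydrogen-bond acceptor entering with 4-methoxyphenyl cannot be tied to it from these four compounds.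

On these data alone, every group at this position is an aryl group on a saturated chain carbon bound to a sulfur, so the effect of an amine, a carboxylic acid or a longer chain there remains open. As far as these compounds go, an unsubstituted phenyl would also be needed to show whether methoxy or bromo differs from no substituent at all, and changes to the shared core remain untested in these compounds.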